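A Third Limit and an Untested Dimethyl Amide

This account rests on a few compounds, and the source may have more. Where it says the series, first, only, none or still open, it means among the compounds named here.

In a functional assay on KB cells (Homo sapiens) for inhibition, read by sulforhodamine B assay, with a stated time of 72 h (a lower number here means a stronger inhibitor of growth, a higher number a weaker inhibitor of growth), compound 1 (`O=C(O)/C=C/c1ccncc1-c1ccc2ccccc2c1`) gives > 10000 nM as a limit of the assay, not a number. Compound 2 (`O=C(CCc1ccncc1-c1ccc2ccccc2c1)N1CCOCC1`) gives > 10000 nM as a limit too. Compound 3 (`CNC(=O)CCc1ccncc1-c1ccc2ccccc2c1`) also gives only a limit, > 10000 nM in this assay and no number. The data so far come down to one reading (the limit of > 10000 nM in this assay, at which 3 of the 3 values shown sit) and do not rank the three compounds.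

Compound 4 (`CN(C)C(=O)/C=C/c1ccncc1-c1ccc2ccccc2c1`) carries 2-(dimethylcarbamoyl)ethenyl in place of 2-(methylcarbamoyl)ethyl on an aromatic carbon, opposite the ring nitrogen (2-(dimethylcarbamoyl)ethenyl in place of 2-(methylcarbamoyl)ethyl on an aromatic carbon). Going by the values given here, two measured steps bear on this change, one for the chain (a step that the two limits leave unreadable from compound 1 to compound 3) and one for the group on the carbonyl carbon (a step that the two limits leave unreadable from compound 2 to compound 3), and neither has a readable size. No step beyond the scatter is therefore expected in this assay, and the estimated step (a step that the limit leaves unreadable from compound 3 to compound 4) has no firm direction. For compound 4 the estimated value is 15000 nM with an expected range from 4000 nM to 50000 nM and most likely only a limit will be reported.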

Compound 4, concentration for 50% growth inhibition: 7760 nM
Compound 4: the middle estimate sits 1.9-fold (0.29 log units) above what was measured, within the range that was stated.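

Compound 4 is the only compound shown that gives a number rather than a limit in this assay, while the others stay at a single reading: the limit of > 10000 nM in this assay, at which 3 of the 4 values shown sit.

Putting 2-(dimethylcarbamoyl)ethenyl in place of 2-(methylcarbamoyl)ethyl gives an at least 1.2-fold lower number from compound 3 to compound 4 (0.11 log units; that floor lies within the scatter), and dimethylamino in place of hydroxy on the carbonyl carbon gives an at least 1.2-fold lower number from compound 1 to compound 4 (0.11 log units; that floor lies within the scatter). Each of these is only a floor set by a limit, so the true size of neither step can be read, and the steps among the three earlier compounds remain unreadable as well.

The change from compound 3 alters the chain and the group on the amide nitrogen together, and the compounds shown do not separate the two. How 2-(methylcarbamoyl)ethenyl would read is open, as is whether diethylamino or piperidin-1-yl on the carbonyl carbon would give a lower number.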